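The compounds below may be only part of what the source reports. "The series", "measured", "known", "first", "only" and "open" are said of these compounds alone.

Working notes on a small set built around a shared core. For the measured compounds named here, compound 1 `COc1ccc(C(=O)Nc2ccccc2F)cc1OC1CCCC1` is the only member with a number in an assay on isolated protein for inhibition of phosphodiesterase 4A (Sus scrofa); a higher number here means a weaker inhibitor, a lower number a stronger inhibitor: compound 1 gives 10700 nM. Compound 2 `COc1ccc(C(=O)Nc2ccccc2Cl)cc1OC(=O)C1CCCC1` returns only a limit in this assay, > 1000000 nM. Compound 3 `COc1ccc(C(=O)Oc2c(Cl)cccc2Cl)cc1OC1CCCC1` likewise returns only a limit, > 1000000 nM. Going by the values given here, the set is dominated by the limit of > 1000000 nM in this assay, at which 2 of the 3 values shown sit, so no step between measured compounds can be read, and compound 1 stands alone as the sole reference point. Compound 4 `COc1ccc(C(=O)Nc2cnccn2)cc1OC1CCCC1` has not yet been measured; it differs from compound 1 by pyrazin-2-yl in place of 2-fluorophenyl on an amide-type nitrogen. Without a measured step to lean on, this change is expected to shift the read-out modestly toward a stronger inhibitor, a 2.1-fold lower number from compound 1 to compound 4 (0.33 log units; beyond the scatter), a step at or only just beyond the usual scatter. Compound 4 is therefore estimated at 5000 nM in this assay, with a range from 1000 nM to 25000 nM.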

Compound 4, half-maximal inhibitory concentration: 250 nM
The estimate for compound 4 lay 20-fold (1.30 log units) above the measured number; measured number outside the range, below it.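

On the amide-type nitrogen, the group carried matters strongly in this assay: pyrazin-2-yl in place of 2-fluorophenyl gives a 43-fold lower number from compound 1 to compound 4 (1.63 log units; beyond the scatter). A ring with 2 hetero atoms and 2 hydrogen-bond acceptors is therefore accepted here, and compound 4 joins compound 1 as a second numerical reference point. Nothing measured here says what lies behind this step.

The steps to compound 2 and compound 3 cannot be read, as both values are limits. Going by these compounds, it remains open whether pyridin-2-yl or pyrimidin-2-yl on the same nitrogen would keep the lower number.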